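A few compounds are considered here, and "the series" means these few. Any claim that something is new, unique, unknown or untested is made for them only; others in the source may bear on it.

Within the data shown here, in a functional assay on MC-38 cells (Mus musculus) for antiproliferative activity, read by colorimetric assay and MTT assay (on this read-out higher numbers stand for weaker inhibition and lower numbers for stronger inhibition), three compounds have numbers so far. Compound 1 `O=S(=O)(Nc1cccc2c(Cl)c[nH]c12)c1ccc(Cl)cc1` gives 0.28 ug/mL, compound 2 `Nc1ccc(S(=O)(=O)Nc2ccc(F)c3c(Cl)c[nH]c23)cc1` gives 0.11 ug/mL, and compound 3 `Nc1ccc(S(=O)(=O)Nc2ccc(Br)c3c(Cl)c[nH]c23)cc1` gives 0.14 ug/mL. The number for compound 3 cannot be told apart from that of compound 2 or that of compound 1, since it lies within the usual scatter of repeated measurements of both.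

The next compound is compound 4 `Nc1ccc(S(=O)(=O)Nc2ccc(-c3ccccc3)c3c(Cl)c[nH]c23)cc1`, which is compound 3 with one change: phenyl in place of bromo on an aromatic carbon. In short, phenyl takes the place of bromo on an aromatic carbon. Among the measured compounds shown here, only one measured step bears on this change, the swap of fluoro for bromo on that same carbon: a 1.3-fold higher number from compound 2 to compound 3 (0.10 log units; within the scatter). That step is small and stays within the scatter, so it offers no sign that this group strongly moves the number. However, it covers only two single-atom groups, and no compound with a ring at this carbon has been measured. The forecast is therefore uncertain, and only a slight shift towards weaker inhibition is expected. The expected change is a 1.6-fold higher number from compound 3 to compound 4 (0.20 log units; within the scatter), which is not a step beyond the scatter. For compound 4 the estimated value is 0.22 ug/mL, with an expected range from 0.07 ug/mL to 0.7 ug/mL.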

Compound 4, half-maximal inhibitory concentration: 19 ug/mL
Compound 4: middle estimate off by 86-fold (1.94 log units), on the low side; the whole stated range lies below it.
By their numbers in this assay, from the lowest: compounds 2, 3 and 1 (each within the scatter of the next, the first and the last beyond it); then compound 4.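

In this assay, the carbon carrying fluoro or bromo proves far from indifferent to the group placed on it: phenyl gives a 140-fold higher number from compound 3 to compound 4 (2.13 log units; beyond the scatter), and the comparison with fluoro gives a 170-fold higher number from compound 2 to compound 4 (2.24 log units; beyond the scatter). The earlier step between fluoro and bromo stayed within the scatter, so it gave no hint that this position could move the number so strongly. The change brings in one six-membered aromatic ring of carbon only, with 6 heavy atoms where bromo has 1, but nothing available explains why inhibition becomes so much weaker, so the result remains an observation without an established cause.

The compounds shown leave open whether a methyl group, a methoxy group, a saturated cyclohexyl ring or a phenyl ring carrying an amine or a carboxylic acid would keep inhibition close to that of compound 3 or weaken it as phenyl does. They also leave open whether phenyl at this carbon would have as large an effect on a compound carrying the chloro group of compound 1 in place of the amino group.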